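This account rests on a few compounds, and the source may have more. Where it says the series, first, only, none or still open, it means among the compounds named here.

Compound 1 `COc1cc(OCCOCCNC2CCCC2)ccc1OCc1ccccc1`: 44600 nM
Compound 2 `O=[N+]([O-])c1cccc(COc2ccc(OCCOCCNC3CCCC3)cc2)c1`: 15400 nM
Compound 3 `c1ccc(COc2ccc(OCCOCCNC3CCCCC3)cc2)cc1`: 7370 nM

Of the compounds shown here, three have been measured in a functional assay on SK-OV-3 cells (Homo sapiens) for inhibition, read by CCK-8 assay, with a stated time of 70 h; a lower number here means a stronger inhibitor, a higher number a weaker inhibitor. Compound 2 gives 15400 nM, the second highest of the three numbers. Its nearest neighbour, compound 3, gives 7370 nM, a lower number by a margin beyond the usual scatter, so compound 3 is the stronger inhibitor of the two. Compound 1 gives 44600 nM, a higher number than compound 2 and again beyond the scatter, so compound 1 is the weaker of that pair.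

The next compound, compound 4 `COc1ccc(OCCOCCNC2CCCC2)cc1`, has not been measured. Compared with compound 2 it carries one change: hydrogen in place of 3-nitrophenyl on a saturated chain carbon bound to an oxygen on an aromatic ring. For the measured compounds named here, nothing among the measured compounds isolates this particular change, so the expectation rests on the general picture that a whole aromatic group is lost and only a hydrogen remains on the saturated chain carbon bound to an oxygen on an aromatic ring.

Losing so much of the molecule is expected to weaken inhibition rather than strengthen it. The estimated step is a 2.6-fold higher number from compound 2 to compound 4 (0.41 log units; beyond the scatter), a clear move beyond the scatter toward a higher number. Compound 4 is therefore expected to give about 40000 nM in this assay, within a range from 12000 nM to 130000 nM.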

Compound 4, half-maximal inhibitory concentration: 99100 nM
The estimate for compound 4 lay 2.5-fold (0.39 log units) below the measured number; measured number inside the range.
By their numbers in this assay, from the lowest: compound 3; then compound 2; then compound 1; then compound 4.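

In this assay, for the compounds shown here, placing hydrogen in place of 3-nitrophenyl on a saturated chain carbon bound to an oxygen on an aromatic ring gives a 6.4-fold higher number from compound 2 to compound 4 (0.81 log units; beyond the scatter), and this is the first pair in the set that differs in only one place. It shows that this position is not indifferent to what it carries: with the 3-nitrophenyl gone, inhibition weakens by a margin beyond the usual scatter, even though the step counts as modest. Nothing shown here gives a measured reason for this step.

The compounds shown leave open how much of the step belongs to the aromatic ring and how much to the nitro group on it, and a plain phenyl, a 3-aminophenyl or a short ethyl chain in the same place on the core of compound 4 would help to separate the two. Compound 1 and compound 3 each differ from compound 2 in more than one place, so neither can settle that question.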